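The source may hold more compounds than are shown below. What is called first, only, known or untested is meant among the compounds shown, and "the series" means these compounds.

Measured so far in a functional assay on MCF7 cells (Homo sapiens) for inhibition, read by MTT assay, with a stated time of 72 h; a higher number here means a weaker inhibitor, a lower number a stronger inhibitor:
- compound 1 `CCC/C=C/C(=O)Nc1cccc(Oc2nc(Nc3cccc(OC)c3)nc3ccsc23)c1` gives 5020 nM
- compound 2 `C=CC(=O)Nc1cccc(Oc2nc(Nc3cccc(C#N)c3)nc3ccsc23)c1` gives 19000 nM
- compound 3 `CC(C)/C=C/C(=O)Nc1cccc(Oc2nc(Nc3cccc(C#N)c3)nc3ccsc23)c1` sits at the assay limit, > 50000 nM

Compound 3 carries a nitrile on one side of the shared core and a branched chain on the amide. Its number in this assay is not a measured value but a limit: compound 3 reaches (the limit of > 50000 nM in this assay, at which 1 of the 3 values shown sits), so only a floor for its weakness is known. Within the data shown here, the one step that reaches it, an at least 2.6-fold higher number from compound 2 to compound 3 (0.42 log units; beyond the scatter), runs from a short vinyl group to the branched chain and already moves the number to that limit.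

Compound 4 `CCC/C=C/C(=O)Nc1cccc(Oc2nc(Nc3cccc(C#N)c3)nc3ccsc23)c1` is the next compound to be tested. It differs from compound 3 in a single spot: propyl in place of isopropyl on a double-bonded chain carbon bound to a double-bonded chain carbon. The same unbranched chain on a methoxy-bearing core is seen in compound 1, while the short vinyl group on the nitrile core is seen in compound 2, so a modest return toward numbers below the limit is expected. The expected step of an at least 2.5-fold lower number from compound 3 to compound 4 (0.39 log units; beyond the scatter) is a downward one, and compound 4 is estimated at 20000 nM, between 6000 nM and 60000 nM.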

Compound 4, half-maximal inhibitory concentration: 49100 nM
For compound 4 the middle estimate is 2.5-fold (0.39 log units) below the measured one, within the range that was stated.
By their numbers in this assay, from the lowest: compound 1; then compound 2; then compound 4. At a limit, above all of these: compound 3.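

The number for compound 3 is a limit and not a measurement, so the size of the change from isopropyl to propyl at this spot cannot be given: the limit of > 50000 nM in this assay, at which 1 of the 4 values shown sits. The step itself (an at least 1.0-fold lower number from compound 3 to compound 4 (0.00 log units; that floor lies within the scatter)) therefore sets no order between the two chains. What is new is that the unbranched pent-1-en-1-yl chain, like the branched one, gives a weaker number than vinyl on the same core (a 2.6-fold higher number from compound 2 to compound 4 (0.41 log units; beyond the scatter)), and that with this chain held fixed, cyano gives a weaker number than methoxy (a 9.8-fold higher number from compound 1 to compound 4 (0.99 log units; beyond the scatter)).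

Still open, going by these compounds, is whether a longer chain, or a chain carrying an amine, would lower the number on the cyano-bearing compounds. Also open, on these data alone, is how vinyl would behave on the methoxy-bearing core.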